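The source may hold more compounds than are shown below. What is called first, only, known or untested is meant among the compounds shown, and "the series" means these compounds.

Two ureas on the shared core have been measured. Compound 1 `O=C(Nc1ccccc1F)Nc1cc2ncncc2cc1OCc1cccc(F)c1` gives 8100 nM in a functional assay on GBM3 cells (Homo sapiens) for antiproliferative activity, read by WST assay, with a stated time of 72 h; on this read-out lower numbers stand for stronger inhibition and higher numbers for weaker inhibition. Compound 2 `O=C(Nc1ccc(Cl)c(Cl)c1)Nc1cc2ncncc2cc1OCc1cccc(F)c1` gives 2000 nM in this assay. Among the compounds with values here, the one step between them, a 4.1-fold lower number from compound 1 to compound 2 (0.61 log units; beyond the scatter), shows that exchanging the aryl group on the amide-type nitrogen moves the number by more than the scatter. Within the data shown here, on the numbers so far compound 2 stands with the lowest value; its nearest neighbour is compound 1, whose number is higher by that same step.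

Compound 3 `O=C(Nc1cc2ncncc2cc1OCc1cccc(F)c1)Nc1cccc2ccccc12` has not yet been measured. It differs from compound 2 by naphthalen-1-yl in place of 3,4-dichlorophenyl on an amide-type nitrogen. Among the measured compounds shown here, the only measured step that bears on this change is a 4.1-fold lower number from compound 1 to compound 2 (0.61 log units; beyond the scatter), which touches the same aryl group at the same place and was modest in size. For the measured compounds named here, no measured compound carries a naphthalen-1-yl group, so the direction of the new step is open. The expectation is that compound 3 gives 2500 nM in this assay, with a range from 800 nM to 8000 nM. The expected step of a 1.3-fold higher number from compound 2 to compound 3 (0.10 log units; within the scatter) is estimated to lie within the scatter.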

Compound 3, half-maximal inhibitory concentration: 1200 nM
For compound 3 the middle estimate is 2.1-fold (0.32 log units) above the measured one; the range from low to high includes it.
By their numbers in this assay, from the lowest: compounds 3 and 2 (each within the scatter of the next); then compound 1.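

In this assay the exchange of 3,4-dichlorophenyl for naphthalen-1-yl gives a 1.7-fold lower number from compound 2 to compound 3 (0.22 log units; within the scatter) and so does not separate the two groups, which shows that a group of two six-membered aromatic rings of carbon only, with no chlorine, can stand on the amide-type nitrogen and keep the number of the dichlorinated ring. Measured against the 2-fluorophenyl group, the same naphthalen-1-yl group gives a 6.8-fold lower number from compound 1 to compound 3 (0.83 log units; beyond the scatter) and thereby joins 3,4-dichlorophenyl on the same side of that group, leaving compound 1 apart from the other two ureas in this small set. Nothing measured on these compounds bears on what lies behind these differences.

From the compounds shown here alone, whether the level shared by compound 2 and compound 3 holds for naphthalen-2-yl, for a saturated cyclohexyl ring or for a phenyl ring carrying a carboxylic acid stays open. The compounds shown also leave open how far this aryl exchange carries over when the rest of the shared core is changed, for example with an amine in a longer chain on the ether side.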